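Swapping the aryl amide for cyclopropyl: what to expect

A few compounds are considered here, and "the series" means these few. Any claim that something is new, unique, unknown or untested is made for them only; others in the source may bear on it.

Compound 1 `CN1C[C@H](C(=O)Nc2ccc(Br)cc2)[C@@H](c2ccc(/C=C/C(=O)Nc3ccccc3N)cc2)C1` is a cinnamoyl-linked benzamide bearing a 4-bromophenyl amide on the shared core. In an in vitro ADME assay on microsomes from liver (Mus musculus) for pharmacokinetics, read by LC-MS, with a stated time of 10 min, tested at 1 uM (a higher number here means faster removal of the compound, a lower number slower removal), compound 1 gives 16 mL/min/kg, the lowest of the three numbers in hand. Compound 2 `COc1cccc(NC(=O)[C@H]2CN(C)C[C@@H]2c2ccc(/C=C/C(=O)Nc3ccccc3N)cc2)c1` gives 65 mL/min/kg and compound 3 `Cc1cc(NC(=O)[C@H]2CN(C)C[C@@H]2c2ccc(/C=C/C(=O)Nc3ccccc3N)cc2)ccc1Cl` gives 65 mL/min/kg in this assay. The two measured steps away from compound 1 both point the same way: a 4.1-fold higher number from compound 1 to compound 2 (0.61 log units; beyond the scatter) and a 4.1-fold higher number from compound 1 to compound 3 (0.61 log units; beyond the scatter), while no change at the digits printed from compound 2 to compound 3 (within the scatter).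

Compound 4 `CN1C[C@H](C(=O)NC2CC2)[C@@H](c2ccc(/C=C/C(=O)Nc3ccccc3N)cc2)C1` differs from compound 1 by cyclopropyl in place of 4-bromophenyl on an amide-type nitrogen. Among the measured compounds shown here, no measured step covers a ring exchange of this kind; both known steps replace one aryl group with another and each raises the number by the same modest amount. For the measured compounds named here, on that basis a modest rise is expected for compound 4, with wide uncertainty because the only guide is a 4.1-fold higher number from compound 1 to compound 2 (0.61 log units; beyond the scatter) in a different direction of change. Compound 4 is therefore estimated at 32 mL/min/kg in this assay, with a range from 10 mL/min/kg to 100 mL/min/kg, which corresponds to an expected step of a 2.0-fold higher number from compound 1 to compound 4 (0.30 log units; within the scatter).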

Compound 4, clearance: 7 mL/min/kg
The estimate for compound 4 lay 4.6-fold (0.66 log units) above the measured number, outside the stated range (below it).
By their numbers in this assay, from the lowest: compound 4; then compound 1; then compounds 2 and 3 (each within the scatter of the next).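

In this assay, the amide-type nitrogen of the shared core need not carry an aryl group: cyclopropyl in place of 4-bromophenyl gives a 2.3-fold lower number from compound 1 to compound 4 (0.36 log units; beyond the scatter), the first step away from compound 1 that lowers the number rather than raises it. The gap is wider against the other two aryl amides, with a 9.3-fold lower number from compound 3 to compound 4 (0.97 log units; beyond the scatter) and a 9.3-fold lower number from compound 2 to compound 4 (0.97 log units; beyond the scatter), which places compound 4 beyond the scatter from all three. Nothing available explains why the number falls with this exchange.

From the compounds shown here alone, whether the lower number goes with the cyclopropyl ring itself or simply with the loss of an aryl ring stays open. So does how a cyclobutyl or cyclohexyl ring, an isopropyl group or a short chain ending in an amine would read on this nitrogen.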